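Trifluoromethyl in place of fluoro: compound 1 to compound 4

This account rests on a few compounds, and the source may have more. Where it says the series, first, only, none or still open, it means among the compounds named here.

- compound 1 `C=C(CC(=O)Nc1ccc(F)cc1F)C(=O)O`: > 110000 nM
- compound 2 `C=C(CC(=O)Nc1ccc(Cl)cc1F)C(=O)O`: > 110000 nM
- compound 3 `C=C(CC(=O)Nc1ccc(C(F)(F)F)cc1F)C(=O)O`: > 110000 nM

In an ADME assay on MDCK cells (Canis lupus familiaris) for cytotoxicity, read by MTT assay, with a stated time of 72 h (on this read-out higher numbers stand for lower toxicity in this test and lower numbers for higher toxicity in this test), compound 1 gives > 110000 nM, which is a limit and not a number. All measured compounds stand at the limit of > 110000 nM in this assay, at which 3 of the 3 values shown sit. Compound 4 `C=C(CC(=O)Nc1ccc(F)cc1C(F)(F)F)C(=O)O` differs from compound 1 by trifluoromethyl in place of fluoro on an aromatic carbon. The closest evidence is a step that the two limits leave unreadable from compound 1 to compound 3, the same exchange of groups on another aromatic carbon. Also relevant are a step that the two limits leave unreadable from compound 1 to compound 2 and a step that the two limits leave unreadable from compound 2 to compound 3. None of these gives a readable size, so no step beyond the scatter is expected in this assay, and a further limit is the likeliest report. The expected step is a step that the limit leaves unreadable from compound 1 to compound 4. For compound 4 the estimate is 130000 nM, with an expected range of 70000 nM to 260000 nM.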

Compound 4, half-maximal cytotoxic concentration: > 110000 nM
Compound 4 ended at the assay's limit (the forecaster's own chance of this, stated with the estimate: 90%); the middle value is on the limit's open side.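

Compound 4 and compound 1 both give only a limit in this assay, so no step between them can be read: the limit of > 110000 nM in this assay, at which 4 of the 4 values shown sit.

The compounds shown leave open whether any exchange on the shared core would give a readable value in this assay.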